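The source may hold more compounds than are shown below. What is called first, only, known or untested is meant among the compounds shown, and "the series" means these compounds.

The series shares one core, shown in compound 1 `Cc1ccc(-c2cn(CCNc3nonc3/C(=N/O)Nc3ccc(F)c(Br)c3)nn2)cc1`, compound 2 `O/N=C(\Nc1ccc(F)c(Br)c1)c1nonc1NCCn1cc(-c2cccc(O)c2)nn1`, compound 3 `CC(O)c1cn(CCNc2nonc2/C(=N/O)Nc2ccc(F)c(Br)c2)nn1` and compound 4 `OCCOCc1cn(CCNc2nonc2/C(=N/O)Nc2ccc(F)c(Br)c2)nn1`, and differs only in the group carried on the five-membered ring with three nitrogens. In an assay on tissue (HeLa cells) for inhibition of Indoleamine 2,3-dioxygenase 1 (Homo sapiens), read by spectrophotometry, with a stated time of 48 h (a higher number here means a weaker inhibitor, a lower number a stronger inhibitor), compound 2 gives 13.6 nM. For compound 1 the entry in this assay reads "not determined" (no result reported), and for compound 3 it reads "not determined" (no result reported), so compound 3 stands without a single number, and a second entry in the set is likewise without one. No step between two measured compounds is shown, and nothing in the numbers ties the group on that ring to a direction of change.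

The move from compound 3 to compound 4 is (2-hydroxyethoxy)methyl in place of 1-hydroxyethyl on an aromatic carbon. With compound 3 unmeasured, no step can be read off for this change; the only anchor is compound 2 at 13.6 nM, and whether compound 4 lands beyond the scatter of that value in either direction cannot be told from what is shown. Compound 4 is therefore expected to lie near 40 nM in this assay, in the range 8 nM to 250 nM.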

Compound 4, half-maximal inhibitory concentration: 2.16 nM
Compound 4: middle estimate off by 19-fold (1.27 log units), on the high side; measured number outside the range, below it.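

In this assay, among the compounds shown here, (2-hydroxyethoxy)methyl in place of 3-hydroxyphenyl on an aromatic carbon of the five-membered aromatic ring with 3 nitrogen gives a 6.3-fold lower number from compound 2 to compound 4 (0.80 log units; beyond the scatter), the first step that can be read and one that lies beyond the scatter. At this position, then, an aryl group is not needed for a low number: compound 4, which has no ring in this group, gives 2.16 nM, although this rests on a single pair, and the steps that involve compound 1 or compound 3 cannot be read. Nothing shown here accounts for the size or direction of this step.

The compounds shown leave open how much of the step comes from losing the 3-hydroxyphenyl ring and how much from the particular chain that replaces it, and whether the 1-hydroxyethyl of compound 3 would already give a comparable number. From the compounds shown here alone, it also remains open how the number would respond to an amine or a carboxylic acid at the end of the chain, or to a longer chain.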